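Ester-ring substitution: from compound 2 to compound 3

The compounds below may be only part of what the source reports. "The series", "measured", "known", "first", "only" and "open" are said of these compounds alone.

Measured so far in a functional assay on HepG2 cells (Homo sapiens) for inhibition, read by MTT assay, with a stated time of 72 h; on this read-out higher numbers stand for weaker inhibition and lower numbers for stronger inhibition:
compound 1 `COc1ccc(C(=O)OC2(C(=O)Nc3ccc([N+](=O)[O-])cc3)CCCCC2)cc1` gives 57.1 nM
compound 2 `O=C(OC1(C(=O)Nc2ccc([N+](=O)[O-])cc2)CCCCC1)c1ccccc1` gives 734 nM

For the measured compounds named here, compound 2 stands at the highest of the two numbers in this assay, with compound 1 as its only neighbour, a step of a 13-fold higher number from compound 1 to compound 2 (1.11 log units; beyond the scatter) apart. Compound 3 `CC(=O)Oc1ccccc1C(=O)OC1(C(=O)Nc2ccc([N+](=O)[O-])cc2)CCCCC1` differs from compound 2 by acetoxy in place of hydrogen on an aromatic carbon. Going by the values given here, only one measured step bears on this change, and only loosely: a 13-fold higher number from compound 1 to compound 2 (1.11 log units; beyond the scatter), which shows that a single substituent on the aromatic ring of the ester can move this assay by a large step. The group entering in compound 3 is a different one and sits at a different place, ortho to a large group, so neither the size nor the direction of the methoxy step can simply be carried over. The expectation for compound 3 is therefore a move toward lower numbers that is smaller than the methoxy step, or none beyond the scatter, taken as a 1.8-fold lower number from compound 2 to compound 3 (0.26 log units; within the scatter). Compound 3 is estimated at 400 nM in this assay, within 100 nM to 1600 nM.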

Compound 3, half-maximal inhibitory concentration: 17.7 nM
For compound 3 the middle estimate is 23-fold (1.35 log units) above the measured one; the whole stated range lies above it.
By their numbers in this assay, from the lowest: compound 3; then compound 1; then compound 2.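

In this assay, the bare phenyl ester of compound 2 proves far from the low end of the series: acetoxy on an aromatic carbon, ortho to a large group, gives a 41-fold lower number from compound 2 to compound 3 (1.62 log units; beyond the scatter). That step shows that a substituent at this place can lower the number strongly, and the change of 2-acetoxyphenyl for 4-methoxyphenyl gives a 3.2-fold lower number from compound 1 to compound 3 (0.51 log units; beyond the scatter), which puts compound 3 lowest of the three, with its steps to both others beyond the scatter. No measurement at hand accounts for either step.

The compounds shown leave open whether the gain belongs to acetoxy as a group or to its place on the ring, since only one substituted ring carries a group ortho to a large group and the methoxy of compound 1 is a different group at a different place. A hydroxy group, a methoxy group or a longer acyloxy chain such as propionyloxy at this same place, and acetoxy elsewhere on the ring, would bear on that question.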